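The source may report more compounds than this note shows. Statements on the series, on what has been measured and on what is new or still open speak of the compounds shown alone.

Measured compounds:
compound 1 `COc1cc(C)cc(-c2c(-c3ccnc(-c4ccc(N(C)C)cc4)c3)cnn2CC#N)c1`: 30 nM
compound 2 `COc1cc(C)cc(-c2nn(CC#N)cc2-c2ccnc(-c3ccc(N(C)C)cc3)c2)c1`: 204 nM

In a functional assay on OVCAR-3 cells (Homo sapiens) for inhibition, read by sulforhodamine B assay, with a stated time of 48 h (a lower number here means a stronger inhibitor of growth, a higher number a weaker inhibitor of growth), compound 1 gives 30 nM. In the same assay compound 2 gives 204 nM. Of the two numbers, compound 2 has the higher one; its nearest neighbour is compound 1, whose number is lower by a gap beyond the usual scatter. Going by the values given here, no single-point step connects the two compounds, so all that can be said of the pair is what the two values show.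

Compound 3 `Cc1cc(O)cc(-c2nn(CC#N)cc2-c2ccnc(-c3ccc(N(C)C)cc3)c2)c1` is the next member. It differs from compound 2 in one place: hydrogen in place of methyl on an oxygen on an aromatic ring. Cut one bond further out, the change reads methoxy to hydroxy, or 3-methoxy-5-methylphenyl to 3-hydroxy-5-methylphenyl. Among the compounds with values here, no measured pair carries this change, so there is no anchor for its size or direction. The expectation is a small step, at most modestly toward a higher number, a 1.5-fold higher number from compound 2 to compound 3 (0.17 log units; within the scatter), not clearly beyond the scatter. For compound 3 in this assay the estimate is 300 nM, with a range from 100 nM to 900 nM.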

Compound 3, concentration for 50% growth inhibition: 1910 nM
Estimate against measurement, compound 3: 6.4-fold (0.80 log units) below; measured number above the stated range.
By their numbers in this assay, from the lowest: compound 1; then compound 2; then compound 3.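

In this assay, going by these compounds alone, the first single-place step (a 9.4-fold higher number from compound 2 to compound 3 (0.97 log units; beyond the scatter)) shows that this oxygen position is sensitive to substitution: going from methoxy to hydroxy on the aromatic ring, with only the methyl leaving and the rest of compound 2 unchanged, moves the number well beyond the usual scatter. Within the data shown here, the pair of compound 1 and compound 2 could show only two values with no single-place step between them, whereas this step ties a large change in growth inhibition to one named group on the 3-methoxy-5-methylphenyl substituent. No measurement at hand bears on the reason for the size of this step.

The compounds shown leave open whether the step follows the size of the group on this oxygen, which an ethoxy group or a longer alkoxy chain would test, and whether the oxygen itself is needed, which fluorine or an amine at the same place would test. From the compounds shown here alone, it also remains open whether the methoxy to hydroxy change carries the same size on the core of compound 1.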